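Moving the Methoxy Group Around the Phenyl Ether

A few compounds are considered here, and "the series" means these few. Any claim that something is new, unique, unknown or untested is made for them only; others in the source may bear on it.

Of the compounds shown here, three built on one shared core have been tested in a functional assay on MT4 cells (Homo sapiens) for inhibition; a lower number here means a stronger inhibitor, a higher number a weaker inhibitor. Compound 1 `C/C(=C\COc1c(Cl)cccc1Cl)CC/C=C(\C)C1=CC(=O)C(C)(C)O1` gives 15.5 ug/mL. Compound 2 `COc1cccc(OC/C=C(\C)CC/C=C(\C)C2=CC(=O)C(C)(C)O2)c1` gives 34 ug/mL, and compound 3 `C/C(=C\COc1ccccc1)CC/C=C(\C)C1=CC(=O)C(C)(C)O1` gives 29.4 ug/mL. Among these three numbers compound 3 holds the second highest, closest to compound 2 and furthest from compound 1, yet both of its gaps stay within the scatter: a 1.9-fold higher number from compound 1 to compound 3 (0.28 log units; within the scatter) and a 1.2-fold lower number from compound 2 to compound 3 (0.06 log units; within the scatter). Only a 2.2-fold higher number from compound 1 to compound 2 (0.34 log units; beyond the scatter) reaches beyond it.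

Compound 4 `COc1ccc(OC/C=C(\C)CC/C=C(\C)C2=CC(=O)C(C)(C)O2)cc1` has not yet been measured. It differs from compound 3 by methoxy in place of hydrogen on an aromatic carbon, placed on an aromatic carbon of the six-membered aromatic ring of carbon only. The comparison that bears most on it is a 1.2-fold lower number from compound 2 to compound 3 (0.06 log units; within the scatter), where a methoxy group elsewhere on that same ring made no difference beyond the scatter. For the measured compounds named here, with only that single comparison to go on, the expected step for compound 4 in this assay is a 1.0-fold higher number from compound 3 to compound 4 (0.01 log units; within the scatter), that is, none beyond the scatter. Compound 4 is therefore estimated at 30 ug/mL, with a range from 15 ug/mL to 60 ug/mL.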

Compound 4, half-maximal inhibitory concentration: 33.9 ug/mL
Estimate against measurement, compound 4: 1.1-fold (0.05 log units) below, and the stated range covers the measured number.
By their numbers in this assay, from the lowest: compounds 1, 3, 4 and 2 (each within the scatter of the next, the first and the last beyond it).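

In this assay, going from phenyl to 4-methoxyphenyl, with the methoxy para to a large group, gives a 1.2-fold higher number from compound 3 to compound 4 (0.06 log units; within the scatter) and so shows no effect that can be told from the scatter, just as the methoxy of compound 2 showed none at its own place on the ring. The direct comparison of 3-methoxyphenyl with 4-methoxyphenyl gives a 1.0-fold lower number from compound 2 to compound 4 (0.00 log units; within the scatter) as its step, so moving the methoxy group between these two places makes no readable difference. The third step, a 2.2-fold higher number from compound 1 to compound 4 (0.34 log units; beyond the scatter) in size, is modest and beyond the scatter, and it matches the gap already seen for compound 2, so both methoxy compounds stand apart from the 2,6-dichlorophenyl compound 1 by about the same amount.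

The data shown offer no measured explanation for any of these steps. Still open, as far as these compounds go, is whether an amine, a carboxylic acid or a longer chain such as butoxy at this same ring position would move the number beyond the scatter, and whether a single chlorine there would bring it closer to that of compound 1.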